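Chloro in Place of Methyl on the Core of Compound 1

This account rests on a few compounds, and the source may have more. Where it says the series, first, only, none or still open, it means among the compounds named here.

Measured compounds:
compound 1 `CCOc1ccc(/C=C2\CN(CC(=O)O)c3c(C)cccc3C2=O)cc1` — 42.4%
compound 2 `Cc1cccc2c1N(CC(=O)O)C/C(=C\c1ccc(F)cc1)C2=O` — 22.9%

In an assay on HL-60 cells for inhibition of glutathione S-transferase P (Homo sapiens), read by spectrophotometry, tested at 20 uM (a higher number here means more inhibition at the concentration tested (going by the name of the read-out), a lower number less inhibition), compound 1 gives 42.4%, the highest of the two numbers shown. Among the measured compounds shown here, compound 2 gives 22.9%, and the single measured step of a number 19.5 percentage points lower from compound 1 to compound 2 (beyond the scatter) comes with a fluoro in place of ethoxy on an aromatic carbon.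

Compound 3 `CCOc1ccc(/C=C2\CN(CC(=O)O)c3c(Cl)cccc3C2=O)cc1` differs from compound 1 by chloro in place of methyl on an aromatic carbon. For the measured compounds named here, no measured step touches this part of the shared core: the only step known, a number 19.5 percentage points lower from compound 1 to compound 2 (beyond the scatter), changes a different part of the molecule, so it gives no direct guide to the size of the change here. The expectation therefore rests on compound 1 alone, and the step of a number 0.4 percentage points lower from compound 1 to compound 3 (within the scatter) is expected to stay within the scatter, with no clear direction. Compound 3 is estimated at 42%, with a range from 24% to 60%.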

Compound 3, a percentage reported as inhibition, at one concentration (the size of the read-out at that concentration, not a potency): 59.1%
Beside the measured number, compound 3's estimate is 17.1 percentage points below it; low and high end bracket the measured number.
By their numbers in this assay, from the lowest: compound 2; then compound 1; then compound 3.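

The earlier step changed only the ethoxy group, so it said nothing about the shared core. In this assay, chloro in place of methyl on an aromatic carbon gives a number 16.7 percentage points higher from compound 1 to compound 3 (beyond the scatter), showing that this position, on the six-membered aromatic ring of carbon only, can shift the read-out beyond the scatter even though each group has 1 heavy atom and neither has a hydrogen-bond donor or acceptor. No measurement offered here accounts for the rise.

The compounds shown leave open whether a bromo, a methoxy or an amine at this position would raise the number further or lower it. They also leave open whether chloro would give a similar rise when the ethoxy group is replaced by fluoro, as it is in compound 2.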